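This account rests on a few compounds, and the source may have more. Where it says the series, first, only, none or still open, it means among the compounds named here.

Of the compounds shown here, three of one shared core have been measured in a functional assay on CCRF-CEM cells (Homo sapiens) for inhibition, read by cell counting, with a stated time of 3 days; on this read-out lower numbers stand for stronger inhibition and higher numbers for weaker inhibition. Compound 1 `Nc1cccc(-c2cn3nc(Cc4ccccc4)sc3n2)c1` carries a benzyl group and an unsubstituted aniline; in this assay compound 1 gives 37000 nM. Compound 3 `Cc1ccc(-c2nn3cc(-c4cccc(N)c4)nc3s2)cc1` keeps the free aniline but has 4-methylphenyl in place of benzyl, and compound 3 gives 5900 nM; that swap produced a 6.3-fold lower number from compound 1 to compound 3 (0.80 log units; beyond the scatter). Compound 2 `C=C(Br)C(=O)Nc1cccc(-c2cn3nc(-c4ccc(C)cc4)sc3n2)c1` adds a (1-bromoethenyl)carbonyl group on the aniline nitrogen of compound 3, and compound 2 gives 1700 nM, the lowest number of the three. Removing that group gave a 3.5-fold higher number from compound 2 to compound 3 (0.54 log units; beyond the scatter).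

Compound 4 `C=C(Br)C(=O)Nc1cccc(-c2cn3nc(Cc4ccc(OC)cc4)sc3n2)c1` keeps the (1-bromoethenyl)carbonyl group of compound 2 but alters the other end: 4-methoxybenzyl in place of 4-methylphenyl on an aromatic carbon. Among the compounds with values here, the only step that speaks to this change runs in the opposite direction, from benzyl toward 4-methylphenyl, where the number fell in a 6.3-fold lower number from compound 1 to compound 3 (0.80 log units; beyond the scatter). Returning to a benzyl-type group, now with a methoxy substituent whose effect has not been measured here, is therefore expected to raise the number by a modest step, roughly the size of that earlier one, giving a 4.1-fold higher number from compound 2 to compound 4 (0.61 log units; beyond the scatter). For compound 4 the estimated value in this assay is 7000 nM, with a likely range from 2500 nM to 20000 nM.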

Compound 4, half-maximal inhibitory concentration: 2300 nM
Beside the measured number, compound 4's estimate is 3.0-fold (0.48 log units) above it; measured number outside the range, below it.
By their numbers in this assay, from the lowest: compounds 2 and 4 (each within the scatter of the next); then compound 3; then compound 1.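

With the (1-bromoethenyl)carbonyl group on the aniline nitrogen, putting 4-methoxybenzyl in place of 4-methylphenyl on this aromatic carbon gives a 1.4-fold higher number from compound 2 to compound 4 (0.13 log units; within the scatter) in this assay, so the larger group, with its oxygen, leaves compound 2 and compound 4 indistinguishable on this read-out. The earlier step at the same carbon, a 6.3-fold lower number from compound 1 to compound 3 (0.80 log units; beyond the scatter), was beyond the scatter, but it joined plain benzyl to 4-methylphenyl on the free aniline, so a clear gap between two groups here in one setting does not predict the outcome for a related pair in another. Nothing shown gives a reason for this result.

Still open is how much of this outcome belongs to the methoxy substituent and how much to the (1-bromoethenyl)carbonyl group, since the pair that would separate them, plain benzyl and 4-methoxybenzyl on the same aniline nitrogen, is absent from the compounds shown. Also open, from the compounds shown here alone, is whether this carbon would accept very different groups in the same way, such as a benzyl ring bearing a carboxylic acid or an amine, or a longer chain in place of the ring.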